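From S to R at One Stereocentre

The source may report more compounds than this note shows. Statements on the series, on what has been measured and on what is new or still open speak of the compounds shown alone.

Measured so far in an ADME assay on CHO cells (Cricetulus griseus) for cytotoxicity, read by LDH release (a higher number here means a weaker inhibitor, a lower number a stronger inhibitor), as follows:
Compound 1 `CC(Nc1ccc(Cl)cc1Cl)C(=O)NCc1ccc(F)cc1` gives > 100000 nM as a limit
Compound 2 `CC(Oc1ccc(Cl)cc1Cl)C(=O)NC(C)c1ccc(F)cc1` gives > 100000 nM as a limit
Compound 3 `CC(Oc1ccc(Cl)cc1Cl)C(=O)N[C@@H](C)c1ccc(F)cc1` gives 32000 nM as a number

For the measured compounds named here, compound 3 holds the only true number in this assay and the rest is the limit of > 100000 nM in this assay, at which 2 of the 3 values shown sit, here. Compound 4 `CC(Oc1ccc(Cl)cc1Cl)C(=O)N[C@H](C)c1ccc(F)cc1` differs from it by the two compounds have the same atoms and bonds; at least one stereo element is drawn with a configuration in one of them and without one in the other: 1 of 2 stereo elements differ; a stereocentre at a saturated chain carbon is drawn S in compound 3 and R in compound 4 and the stereocentre concerned sits at a saturated chain carbon. Going by the values given here, one measured step bears on this, namely an at least 3.1-fold lower number from compound 2 to compound 3 (0.49 log units; beyond the scatter) and it goes with the fact that one of compounds 2 and 3 is drawn with a defined configuration and the other without, at the place where they differ alone. Since that step came with drawing the S form, compound 4 with the R form is expected to move the opposite way, to a higher number, possibly reaching the limit. The expected step is a 3.1-fold higher number from compound 3 to compound 4 (0.49 log units; beyond the scatter) in size. For compound 4 the estimate, with its expected range in brackets, is 100000 nM (30000 nM to 300000 nM).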

Compound 4, half-maximal inhibitory concentration: 97000 nM
Compound 4: the middle estimate sits 1.0-fold (0.01 log units) above what was measured; the range from low to high includes it.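

With both configurations now carrying a true number in this assay, the change from S to R at this saturated chain carbon gives a modest step (a 3.0-fold higher number from compound 3 to compound 4 (0.48 log units; beyond the scatter)). The earlier compounds set the S form only against a form drawn without a configuration, whereas here the two defined forms stand directly against each other, with only this centre differing: the fact that one of compounds 3 and 4 is drawn with a defined configuration and the other without, at the place where they differ

Setting the R form against the form drawn without a configuration gives an at least 1.0-fold lower number from compound 2 to compound 4 (0.01 log units; that floor lies within the scatter) as a floor only, since the value of compound 2 is a limit. Going by these compounds, the second stereocentre stays drawn without a configuration in compound 3 and compound 4, and whether the gap between S and R would persist with an ethyl group in place of the methyl on this carbon remains open.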